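The source may report more compounds than this note shows. Statements on the series, on what has been measured and on what is new or still open speak of the compounds shown alone.

Working notes on the series. From the compounds shown here alone, the set holds three measured compounds and one still open. Compound 1 `O=C(NO)c1ccc(-c2cn([C@@H]3C[C@H](C(=O)O)N(Cc4ccccc4)C3)nn2)cc1` carries the hydroxamate on the outer ring and a benzyl on the ring amine. In an assay on Sf9 cells for inhibition of histone deacetylase 11 (Homo sapiens), read by fluorescence, tested at 0.5 uM (a lower number here means less inhibition, a higher number more inhibition at the concentration tested (going by the name of the read-out)), compound 1 gives < 10%, which is a limit of the assay and not a number. Compound 2 `O=C(NO)c1cccc(-c2cn([C@@H]3C[C@@H](C(=O)O)N(Cc4ccccc4)C3)nn2)c1`, the isomer with the hydroxamate moved on its ring, in this assay also gives < 10%, again a limit. Within the data shown here, compound 3 `O=C(NO)c1ccc(-c2cn([C@@H]3C[C@@H](C(=O)O)N(CCCc4ccccc4)C3)nn2)cc1`, with a 3-phenylpropyl on the ring amine, in this assay gives 14%, the only outright number in the set. The other two values, those of compound 1 and compound 2, sit where the limit of < 10% in this assay, at which 2 of the 3 values shown sit, records.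

Compound 4 `O=C(NO)c1ccc(-c2cn([C@@H]3C[C@@H](C(=O)O)N(Cc4ccccc4)C3)nn2)cc1` is not yet measured. It differs from compound 3 by phenyl in place of phenethyl on a saturated chain carbon bound to an amine nitrogen in a ring. Among the measured compounds shown here, no step between measured compounds is known, so the expected step from compound 3 to compound 4 in this assay, a number 4 percentage points lower from compound 3 to compound 4 (within the scatter), is a small drop that may not clear the scatter. Compound 4 is therefore estimated at 10%, between 4% and 18%, with a fair chance that the assay again reports only a limit.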

Compound 4, a percentage reported as inhibition, at one concentration (the size of the read-out at that concentration, not a potency): < 10%
Compound 4 ended at the assay's limit (the forecaster's own chance of this, stated with the estimate: 55%); the middle value lies on the limit itself.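

Among these compounds, the change from 3-phenylpropyl to benzyl on the ring amine gives the first readable step: in this assay it is a number at least 4 percentage points lower from compound 3 to compound 4 (that floor lies within the scatter), so a real loss of inhibition from the shorter chain is not established. The steps to compound 4 from compound 1 and from compound 2 cannot be read, so this result settles neither the swap of 3-(hydroxycarbamoyl)phenyl for 4-(hydroxycarbamoyl)phenyl nor the role of the drawn configuration, even for the closest pair: the fact that compounds 1 and 4 differ only in the configuration as drawn Compound 4 adds one more reading at the floor of the series: the limit of < 10% in this assay, at which 3 of the 4 values shown sit.

From the compounds shown here alone, whether a chain longer than 3-phenylpropyl on the ring amine would lift the reading clear of the scatter stays open. Going by these compounds, the effect of an amide in place of the carboxylic acid also stays open.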